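The source may hold more compounds than are shown below. What is called first, only, known or untested is meant among the compounds shown, and "the series" means these compounds.

Measured compounds:
- compound 1, `Cc1n[nH]c2ccc(-c3nc4cnc(N5CCN(C)CC5)cn4c3Nc3cccc(F)c3)cc12`: "not determined" (no result reported)
- compound 2, `Cc1n[nH]c2ccc(-c3nc4cnc(N5CCN(C)CC5)cn4c3Nc3ccc(Cl)cc3)cc12`: 3510 nM

The account follows one step. Compound 1 was run in a functional assay on MV4-11 cells (Homo sapiens) for inhibition, with a stated time of 120 h (a lower number here means a stronger inhibitor, a higher number a weaker inhibitor), but no number was reported for it. Going by the values given here, compound 2 is therefore the only compound with a numerical result in this assay, and it gives 3510 nM; that figure is the sole reference point, with nothing to rank it against.

Compound 3, `Cc1n[nH]c2ccc(-c3nc4cnc(N5CCN(C)CC5)cn4c3Nc3ccc(Br)cc3)cc12`, differs from compound 2 in one place: bromo in place of chloro on an aromatic carbon. Among the compounds with values here, no measured pair shows what this exchange does in this assay, so no step is on record to lean on.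

Within the data shown here, with only the single value of compound 2 to go by, the exchange of one halogen for another of the same kind is expected to move the inhibitory concentration by no more than the usual scatter, in no firm direction, giving a 1.2-fold lower number from compound 2 to compound 3 (0.07 log units; within the scatter). Compound 3 is accordingly estimated at 3000 nM, within a range from 1200 nM to 8000 nM.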

Compound 3, half-maximal inhibitory concentration: 2600 nM
Beside the measured number, compound 3's estimate is 1.2-fold (0.06 log units) above it; low and high end bracket the measured number.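

In this assay, going by these compounds alone, the change from 4-chlorophenyl to 4-bromophenyl gives a 1.4-fold lower number from compound 2 to compound 3 (0.13 log units; within the scatter), the first step on record at this place, and it sets the two halogens on the same footing. Within the data shown here, the aromatic carbon para to a large group therefore carries either chloro or bromo with no change that can be told from repeat measurements, a reading that the single number of compound 2 could not give. There is no measured information at hand that would explain this outcome.

What the compounds shown leave open is whether the flat reading extends beyond these two halogens: a methoxy group, an amine or a carboxylic acid at the same carbon might give a number clearly apart from those of compound 2 and compound 3. A single pair also cannot say whether the same exchange would read alike if other parts of the shared core carried different groups.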